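Swapping Diethylamino for Cyclobutylamino on a Shared Core

The source may hold more compounds than are shown below. What is called first, only, known or untested is meant among the compounds shown, and "the series" means these compounds.

Of the compounds shown here, three built on one shared core have been measured in an assay on cell membranes for displacement of a labelled ligand from corticotropin-releasing factor receptor 1 (Rattus norvegicus); on this read-out lower numbers stand for stronger inhibition and higher numbers for weaker inhibition. Compound 2 `CCN(CC)c1nc(C)nc2c(-c3c(C)cc(OC)cc3OC)c(C)nn12` gives 1.2 nM, the lowest of the three numbers, although compound 3 `CCCCN(CC)c1nc(C)nc2c(-c3ccc(OC)cc3C)c(C)nn12` with 2.3 nM lies within the usual scatter of it; only compound 1 `COCC(COC)Nc1nc(C)nc2c(-c3ccc(OC)cc3C)c(C)nn12` with 9.7 nM sits clearly beyond. Compound 4 `COc1cc(C)c(-c2c(C)nn3c(NC4CCC4)nc(C)nc23)c(OC)c1` has not yet been measured. It differs from compound 2 in a single place: cyclobutylamino in place of diethylamino on an aromatic carbon.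

For the measured compounds named here, only one measured step touches the same position, namely a 4.2-fold lower number from compound 1 to compound 3 (0.63 log units; beyond the scatter). Going by the values given here, that step ran in the opposite sense, moving from an amino group of the same kind as the one entering compound 4 to a dialkylamino group of the kind leaving compound 2, and it exchanged the whole substituent at once, so it bears on the present change only loosely. Compound 4 turns that direction around while putting a compact ring in place of the two ethyl chains. A modest rise in the number is therefore expected, roughly a 2.5-fold higher number from compound 2 to compound 4 (0.40 log units; beyond the scatter), though a result inside the scatter would not surprise. For compound 4 in this assay a value near 3 nM is estimated, with a likely range from 1 nM to 10 nM.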

Compound 4, half-maximal inhibitory concentration: 17.4 nM
The estimate for compound 4 lay 5.8-fold (0.76 log units) below the measured number; the measured number lies above the stated range.
By their numbers in this assay, from the lowest: compounds 2 and 3 (each within the scatter of the next); then compounds 1 and 4 (each within the scatter of the next).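

The exchange of diethylamino for cyclobutylamino gives a 15-fold higher number from compound 2 to compound 4 (1.16 log units; beyond the scatter) in this assay and shows that this position responds strongly even when the size of the group, counted in atoms, stays the same: both groups have 5 heavy atoms, 4 carbon and 1 nitrogen. What differs is that cyclobutylamino has a four-membered ring of carbon only and a hydrogen-bond donor, whereas diethylamino has no ring and no donor, and this swap moves the number further than the modest earlier step, a 4.2-fold lower number from compound 1 to compound 3 (0.63 log units; beyond the scatter), which replaced a quite different amino group. No measurement at hand accounts for the size of this step.

The ring and the amino hydrogen enter together in compound 4, so the compounds shown cannot say which of the two goes with the higher number. A pyrrolidin-1-yl group, which holds a ring on the nitrogen with no amino hydrogen, and a sec-butylamino group, which keeps the amino hydrogen with no ring, would pull those two changes apart on this core.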